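A Methyl Added Twice, in Two Different Settings

The compounds below may be only part of what the source reports. "The series", "measured", "known", "first", "only" and "open" are said of these compounds alone.

Compound 1 has the structure `CCOC(=O)c1cccc(-c2ccc(CN(C)C)cc2)c1` and in an assay on COS-7 cells for inhibition of patatin-like phospholipase domain-containing protein 2 (Mus musculus) (a higher number here means a weaker inhibitor, a lower number a stronger inhibitor), compound 1 gives 150000 nM. Compound 2 has the structure `CCOC(=O)c1cccc(-c2ccc(C(C)N(C)C)cc2)c1` and in this assay compound 2 gives 200000 nM. Compound 3 has the structure `CCOc1ccc(-c2cccc(C(=O)NC)c2)cc1`. For compound 3 this assay reports only a limit, > 200000 nM, not a number.

Compound 1 and compound 2 differ by methyl in place of hydrogen on a saturated chain carbon bound to an amine nitrogen and an aromatic carbon. This change gave a 1.3-fold higher number from compound 1 to compound 2 (0.12 log units; within the scatter). Compound 3 and compound 4 share a core that is not the core of compound 1; the difference between the two cores is not broken down here.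

Compound 4, with the structure `CCNC(=O)c1cccc(-c2ccc(OCC)cc2)c1`, has not yet been measured in this assay. It differs from compound 3 by methyl in place of hydrogen on a saturated chain carbon bound to an amide-type nitrogen. Among the compounds with values here, this is the same kind of change as the one from compound 1 to compound 2, but not the same: there the added methyl sits on a saturated chain carbon bound to an amine nitrogen and an aromatic carbon, here it sits on a saturated chain carbon bound to an amide-type nitrogen.

The earlier step stayed within the scatter, as a 1.3-fold higher number from compound 1 to compound 2 (0.12 log units; within the scatter) shows, and compound 3 sits at the limit of > 200000 nM in this assay, at which 1 of the 3 values shown sits. The step from compound 3 to compound 4 is therefore expected to be small as well, about a number no higher from compound 3 to compound 4 (the limit leaves the size open). For compound 4 in this assay the expected value is 200000 nM, most likely again reported as a limit, with a range from 100000 nM to 400000 nM.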

Compound 4, half-maximal inhibitory concentration: 90000 nM
Estimate against measurement, compound 4: 2.2-fold (0.35 log units) above; measured number outside the range, below it.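

In this assay, putting ethylcarbamoyl in place of methylcarbamoyl gave an at least 2.2-fold lower number from compound 3 to compound 4 (0.34 log units; beyond the scatter), so the added methyl did not repeat on this core the result it gave on the core of compound 1: the same change on two cores in this assay, a 1.3-fold higher number (0.12 log units; within the scatter) from compound 1 to compound 2 and an at least 2.2-fold lower number (0.34 log units; beyond the scatter) from compound 3 to compound 4, at least 2.9-fold (0.47 log units) apart, beyond the scatter of two such steps

The starting point of this step, compound 3, is held only by a limit and not by a number: the limit of > 200000 nM in this assay, at which 1 of the 4 values shown sits.

The comparison does not show what separates the two steps, as the pairs differ both in their core and in the place of the methyl, on a saturated chain carbon bound to an amine nitrogen and an aromatic carbon in one pair and on a saturated chain carbon bound to an amide-type nitrogen in the other, and two pairs cannot tell these apart.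

The compounds shown leave open whether a longer chain on the amide nitrogen, such as propyl or butyl, would extend the step seen from methylcarbamoyl to ethylcarbamoyl. They also leave open how the same methyl would behave on a third core, for instance one carrying a carboxylic acid in place of the ethyl ester of compound 1.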